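From methyl to bromo on an aromatic carbon

A few compounds are considered here, and "the series" means these few. Any claim that something is new, unique, unknown or untested is made for them only; others in the source may bear on it.

Of the compounds shown here, three sharing one core have been measured in an ADME assay on L6 cells (Rattus norvegicus) for cytotoxicity, read by resazurin assay, with a stated time of 72 h; a lower number here means a stronger inhibitor, a higher number a weaker inhibitor. Compound 1 `OC(c1ccc(Cl)cc1)(c1cccnc1)c1ccccc1Cl` gives 61300 nM, and compound 3 `Cc1ccccc1C(O)(c1ccc(Cl)cc1)c1cccnc1` gives 82000 nM. These two values lie within the scatter of each other, so compound 3 stands level with compound 1. Compound 2 `OC(c1ccc(Cl)cc1)(c1cccnc1)c1ccccc1F` reads > 100000 nM, which is a limit of the assay and not a number.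

Compound 4 `OC(c1ccc(Cl)cc1)(c1cccnc1)c1ccccc1Br` has not yet been measured. It differs from compound 3 by bromo in place of methyl on an aromatic carbon. Within the data shown here, no measured compound carries bromo, so the evidence is indirect and comes from the other exchanges at this place. Methyl in place of chloro gave a 1.3-fold higher number from compound 1 to compound 3 (0.13 log units; within the scatter). Fluoro in place of chloro gave an at least 1.6-fold higher number from compound 1 to compound 2 (0.21 log units; that floor lies within the scatter). Methyl in place of fluoro gave an at least 1.2-fold lower number from compound 2 to compound 3 (0.08 log units; that floor lies within the scatter). None of these three steps is shown to exceed the scatter, although two of them rest on a limit. No change beyond the scatter is therefore expected in this assay. The expected move is a 1.3-fold lower number from compound 3 to compound 4 (0.12 log units; within the scatter). Compound 4 is estimated at 62000 nM, with an expected range from 32000 nM to 100000 nM.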

Compound 4, half-maximal inhibitory concentration: 55200 nM
Compound 4: the middle estimate sits 1.1-fold (0.05 log units) above what was measured; measured number inside the range.
By their numbers in this assay, from the lowest: compounds 4, 1 and 3 (each within the scatter of the next). At a limit, above all of these: compound 2.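

With bromo on this aromatic carbon, ortho to a large group, this assay now has a numerical reading for a third group at this place, and that reading stands level with the other two: a 1.1-fold lower number from compound 1 to compound 4 (0.05 log units; within the scatter), and a 1.5-fold lower number from compound 3 to compound 4 (0.17 log units; within the scatter). Chloro, methyl and bromo therefore cannot be told apart in this assay, and the four exchanges among compounds 1, 3 and 4 show no sign yet that this place is sensitive to which of these three groups it carries. The step from fluoro, an at least 1.8-fold lower number from compound 2 to compound 4 (0.25 log units; that floor lies within the scatter), is only a floor that stays within the scatter, and compound 2 remains the one compound whose reading is a limit and not a number: the limit of > 100000 nM in this assay, at which 1 of the 4 values shown sits.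

From the compounds shown here alone, whether fluoro truly differs from the other three groups therefore stays open, since the true size of its steps cannot be read. Also open, going by these compounds, is whether an amine, a carboxylic acid or a longer chain at this place, or any change elsewhere on the shared core, would move the number beyond the scatter.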